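This account rests on a few compounds, and the source may have more. Where it says the series, first, only, none or still open, it means among the compounds named here.

In a functional assay on A2780 cells (Homo sapiens) for antiproliferative activity, read by resazurin assay, with a stated time of 72 h (on this read-out lower numbers stand for stronger inhibition and higher numbers for weaker inhibition), three amides built on the same core have been read so far. Compound 1 `CCCN(C)C(=O)c1cc2c(Cc3ccccc3)n[nH]c2cc1O` gives > 10000 nM, which is a limit of the assay and not a number. Compound 2 `Cc1ccccc1CN(C)C(=O)c1cc2c(Cc3ccccc3)n[nH]c2cc1O` gives 4400 nM. Compound 3 `COc1cccc(CN(C)C(=O)c2cc3c(Cc4ccccc4)n[nH]c3cc2O)c1OC` gives 4800 nM, which places it level with compound 2, as the comparison shows: a 1.1-fold higher number from compound 2 to compound 3 (0.04 log units; within the scatter).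

Compound 4 `COc1cc(CN(C)C(=O)c2cc3c(Cc4ccccc4)n[nH]c3cc2O)ccc1Cl` has 4-chloro-3-methoxyphenyl in place of 2,3-dimethoxyphenyl on a saturated chain carbon bound to an amide-type nitrogen.

Going by the values given here, three measured steps bear on this change. Putting an aryl group in place of ethyl at this position gave an at least 2.2-fold lower number from compound 1 to compound 2 (0.35 log units; beyond the scatter) and also an at least 2.0-fold lower number from compound 1 to compound 3 (0.31 log units; beyond the scatter). Both of these steps start from a limit, and both replace ethyl rather than one substituted phenyl with another. Among the compounds with values here, the closest precedent is the exchange of 2-methylphenyl for 2,3-dimethoxyphenyl, which gave a 1.1-fold higher number from compound 2 to compound 3 (0.04 log units; within the scatter). In this assay, from the compounds shown here alone, a step beyond the scatter is therefore not expected, and the new chlorine remains untested. The expected change is a 1.2-fold lower number from compound 3 to compound 4 (0.08 log units; within the scatter). The estimate for compound 4 is 4000 nM, with an expected range from 1600 nM to 10000 nM.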

Compound 4, half-maximal inhibitory concentration: 4100 nM
Compound 4: middle estimate off by 1.0-fold (0.01 log units), on the low side; low and high end bracket the measured number.
By their numbers in this assay, from the lowest: compounds 4, 2 and 3 (each within the scatter of the next). At a limit, above all of these: compound 1.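

In this assay, the 4-chloro-3-methoxyphenyl group cannot be told apart from either aryl group already read at this place, with a 1.2-fold lower number from compound 3 to compound 4 (0.07 log units; within the scatter) and a 1.1-fold lower number from compound 2 to compound 4 (0.03 log units; within the scatter). Like those two groups, it lies beyond the scatter when set against ethyl on a saturated chain carbon bound to an amide-type nitrogen, with an at least 2.4-fold lower number from compound 1 to compound 4 (0.38 log units; beyond the scatter). Compound 1 gives > 10000 nM, which is a limit of the assay and not a number, so the full size of that step cannot be read: the limit of > 10000 nM in this assay, at which 1 of the 4 values shown sits.

The compounds shown leave open whether any other group at this place would move the number beyond the scatter from these three aryl groups, for example a pyridine ring, a phenyl ring carrying a carboxylic acid or an amine, or a longer chain between the ring and the amide nitrogen. The chlorine also cannot be judged on its own in this series, and a plain 4-chlorophenyl group or a plain 3-methoxyphenyl group would be needed to separate it from the methoxy group that accompanies it.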